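This account rests on a few compounds, and the source may have more. Where it says the series, first, only, none or still open, it means among the compounds named here.

Measured compounds:
Compound 1, `COc1cc2c(=O)c(C(=O)c3ccc(C)cc3)cn(Cc3ccc(C(C)C)cc3)c2cc1OC`, gives 15500 nM in an ADME assay on Huh-7 cells (Homo sapiens) for cytotoxicity; on this read-out lower numbers stand for stronger inhibition of growth and higher numbers for weaker inhibition of growth.
Compound 2, `COc1cc2c(=O)c(C(=O)OCc3ccc(Cl)cc3)cn(Cc3ccccc3)c2cc1OC`, gives 28300 nM in this assay.

Of the compounds shown here, two built on the shared core have so far been tested for growth inhibition of the liver-derived cells. For the measured compounds named here, compound 1 and compound 2 differ in more than one place, so no single step between them can be read off; what their two values show is that they lie within the scatter of each other, and on the numbers available compound 1 is therefore not set apart from compound 2 in this assay.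

The compound still to be measured is compound 3, `COc1cc2c(=O)c(C(=O)c3ccc(C)cc3)cn(Cc3ccc(C(C)(C)C)cc3)c2cc1OC`. Relative to compound 1 the change is methyl in place of hydrogen on a saturated chain carbon bound to an aromatic carbon and two saturated chain carbons. Going by the values given here, no measured pair in this set carries this change, or any other change in a single place, so there is no step to lean on. The step from compound 1 to compound 3 in this assay is expected to be none beyond the scatter, in either direction, as a 1.1-fold lower number from compound 1 to compound 3 (0.04 log units; within the scatter). Compound 3 is accordingly estimated at 14000 nM, with a range from 6000 nM to 35000 nM.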

Compound 3, concentration for 50% growth inhibition: > 25000 nM
Compound 3: a limit, no number; the forecaster's own chance of this, stated with the estimate: 20%; at least 1.7-fold (0.25 log units) between middle value and limit.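

In this assay compound 3 gives > 25000 nM, which is a limit of the assay and not a number. The change from 4-isopropylbenzyl to 4-(tert-butyl)benzyl supplies the only step in a single place among the compounds shown, and it reads as an at least 1.6-fold higher number from compound 1 to compound 3 (0.20 log units; that floor lies within the scatter). This gives the set its first direct reading at this position: the added methyl on the saturated chain carbon brings no sign of stronger inhibition of growth, although the size of the step cannot be fixed, and the reading for compound 3 gives only a floor: the limit of > 25000 nM in this assay, at which 1 of the 3 values shown sits.

On these data alone, whether the true step lies beyond the scatter stays open, and so does how far the value of compound 3 sits from that of compound 1. Also open, as far as these compounds go, is how the read-out would respond if the tert-butyl gave way at the same place to a longer chain, an amine or a carboxylic acid, any of which would show whether this position tolerates more than the small change from isopropyl to tert-butyl.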